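The source may hold more compounds than are shown below. What is called first, only, known or untested is meant among the compounds shown, and "the series" means these compounds.

Measured in an ADME assay on Vero cells (Chlorocebus sabaeus) for cytotoxicity, read by CellTiter-Glo, with a stated time of 72 h; a lower number here means that less compound is tolerated, a higher number that more compound is tolerated:
- compound 1 `[O-][n+]1nc(NC2CCC2)[n+]([O-])c2ccccc21`: 8.9 ug/mL
- compound 2 `[O-][n+]1nc(NC2CCCC2)[n+]([O-])c2ccccc21`: 10 ug/mL

Only these two numbers exist so far, and compound 2 at 10 ug/mL lies within the scatter of compound 1 at 8.9 ug/mL.

The next structure is compound 3 `[O-][n+]1nc(N2CCCC2)[n+]([O-])c2ccccc21`, with pyrrolidin-1-yl in place of cyclopentylamino on an aromatic carbon, between two ring nitrogen atoms: pyrrolidin-1-yl in place of cyclopentylamino on an aromatic carbon.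

Among the compounds with values here, one measured step bears on this, and only indirectly: a 1.1-fold higher number from compound 1 to compound 2 (0.05 log units; within the scatter). That step swaps cyclobutyl for cyclopentyl and leaves the amine hydrogen in place, whereas the step to compound 3 removes it. Within the data shown here, no measured pair shows that kind of change, so the direction in this assay is open. Among the measured compounds shown here, the small size of the one known step gives weak support for expecting nothing beyond the scatter, and the range is kept wide to allow for this.

The estimated step is a 1.1-fold higher number from compound 2 to compound 3 (0.04 log units; within the scatter).

For compound 3 the expected value is 11 ug/mL, with an estimated range of 4 ug/mL to 28 ug/mL.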

Compound 3, half-maximal cytotoxic concentration: 17 ug/mL
Beside the measured number, compound 3's estimate is 1.5-fold (0.19 log units) below it; the range from low to high includes it.
By their numbers in this assay, from the lowest: compounds 1, 2 and 3 (each within the scatter of the next).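

In this assay, pyrrolidin-1-yl on the aromatic carbon between two ring nitrogen atoms gives a 1.7-fold higher number from compound 2 to compound 3 (0.23 log units; within the scatter), and set against the cyclobutylamino group the same position gives a 1.9-fold higher number from compound 1 to compound 3 (0.28 log units; within the scatter). Within the data shown here, this is the first change that removes the amine hydrogen rather than altering the ring size, and like the earlier ring-size step it stays within the scatter, so neither the hydrogen-bond donor of the amino linkage nor its absence separates these compounds in this read-out. No supporting measurement accounts for these steps.

The three compounds shown leave open whether an open-chain dimethylamino group, a morpholine ring or a longer alkyl chain on this carbon would give a step beyond the scatter. They also leave open what a chlorine or a methoxy group elsewhere on the shared core would do, as only the group on this one carbon varies among them.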